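A few compounds are considered here, and "the series" means these few. Any claim that something is new, unique, unknown or untested is made for them only; others in the source may bear on it.

Of the compounds shown here, three sharing one core have so far been tested in a functional assay on the whole organism (strain Wister albino) for inhibition, with Rattus norvegicus as the target, read by paw edema, with a stated time of 1 h, at a dose of 50 mg/kg by the intraperitoneal route; a lower number here means less inhibition, a higher number more inhibition at the dose given (going by the name of the read-out). Compound 1 `CCOC(=O)c1c(-c2ccc(Cl)cc2)cc(-c2ccccc2)nc1N1CCN(C)CC1` gives 65.8%. Compound 2 `CCOC(=O)c1c(-c2ccc(Cl)cc2)cc(-c2ccccc2)nc1Nc1ccc(C)cc1` gives 69.5%, the step reading a number 3.7 percentage points higher from compound 1 to compound 2 (within the scatter). Compound 3 `CCOC(=O)c1c(-c2ccc(Cl)c(Cl)c2)cc(-c2ccccc2)nc1Nc1ccc(C)cc1` gives 59%, with the step of a number 10.5 percentage points lower from compound 2 to compound 3 (beyond the scatter). Compound 3 thus holds the lowest of the three numbers; its nearest neighbour is compound 1, which lies within the scatter of it, while compound 2 stands beyond the scatter above it.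

Compound 4 `CCOC(=O)c1c(-c2ccc(Cl)c(Cl)c2)cc(-c2ccccc2)nc1Nc1ccc(Cl)cc1` differs from compound 3 in one place: chloro in place of methyl on an aromatic carbon. Put one bond further out, the (4-methylphenyl)amino group becomes a (4-chlorophenyl)amino group, the new chloro sitting para to a large group.

Neither measured step matches this change. The step of a number 10.5 percentage points lower from compound 2 to compound 3 (beyond the scatter) also introduced a chloro, but onto a different ring and in place of hydrogen, and it was modest; the step of a number 3.7 percentage points higher from compound 1 to compound 2 (within the scatter) replaced the whole amino-bearing group and stayed within the scatter. The closest guide is the chloro addition, which suggests at most a small drop; on this slim basis the expected step is a number 3 percentage points lower from compound 3 to compound 4 (within the scatter), not beyond the scatter. Compound 4 is therefore estimated at 56%, within a range of 46% to 66%.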

Compound 4, a percentage reported as inhibition, in the whole organism at one dose (the size of the read-out at that dose, not a potency): 46.2%
Compound 4: the middle estimate sits 9.8 percentage points above what was measured; the range from low to high includes it.
By their numbers in this assay, from the lowest: compound 4; then compounds 3, 1 and 2 (each within the scatter of the next, the first and the last beyond it).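

Chloro in place of methyl on the aromatic carbon para to a large group gives a number 12.8 percentage points lower from compound 3 to compound 4 (beyond the scatter) in this assay, so this position responds to the exchange of a single heavy atom, with no hydrogen-bond donors or acceptors on either side of the change. The earlier step at the same attachment, a number 3.7 percentage points higher from compound 1 to compound 2 (within the scatter), replaced the whole group and did not show this; together with a number 10.5 percentage points lower from compound 2 to compound 3 (beyond the scatter), it also leaves compound 4 as the second case among the steps shown where an entering chloro goes with a lower number, though on a different ring and replacing a different group. The data shown give no measured property that accounts for this drop.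

As far as these compounds go, it remains open whether the lower number follows from the chloro arriving or from the methyl leaving, which hydrogen, fluoro, methoxy or a carboxylic acid at the same position could begin to separate. From the compounds shown here alone, it is also open whether the same exchange would give a step of similar size on the compound 2 scaffold, with only one chloro on the other ring, and the read-out at a single dose and time says nothing about potency.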